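The source may report more compounds than this note shows. Statements on the series, on what has been measured and on what is new or still open speak of the compounds shown alone.

In a functional assay on the whole organism for inhibition, with Rattus norvegicus as the target, read by paw edema, with stated times of 1 h and 6 h, at a dose of 0.03 mg/kg by the oral route (on this read-out higher numbers stand for more inhibition at the one dose given (going by the name of the read-out) and lower numbers for less inhibition), the three measured compounds read:

Compound 1 `CC1=NN(C(=O)c2cc3ccccc3oc2=O)C(=O)C1CNc1ccccn1`: 50.3%
Compound 2 `CC1=NN(C(=O)c2cc3ccccc3oc2=O)C(=O)C1CNc1cccc(S(N)(=O)=O)c1`: 79.9%
Compound 3 `CC1=NN(C(=O)c2cc3ccccc3oc2=O)C(=O)C1CNc1ccc(O)c(C(=O)O)c1`: 50.9%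

Compound 1 stands lowest of the three, with compound 3 within the scatter of it and compound 2 beyond. Compound 4 `COc1ccc(NCC2C(=O)N(C(=O)c3cc4ccccc4oc3=O)N=C2C)cc1` differs from compound 1 by 4-methoxyphenyl in place of pyridin-2-yl on an amine nitrogen. Two measured steps start from compound 1: a number 29.6 percentage points higher from compound 1 to compound 2 (beyond the scatter) and a number 0.6 percentage points higher from compound 1 to compound 3 (within the scatter). Only the sulfamoyl-bearing ring moved the read-out beyond the scatter; a differently substituted phenyl left it unchanged. The 4-methoxyphenyl group carries neither substitution, so in this assay a small step is expected for compound 4, perhaps slightly upward, a number 4.7 percentage points higher from compound 1 to compound 4 (within the scatter). Compound 4 is therefore estimated at 55%, within 35% to 75%.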

Compound 4, a percentage reported as inhibition, in the whole organism at one dose (the size of the read-out at that dose, not a potency): 55.1%
Compound 4: middle estimate off by 0.1 percentage points, on the low side, and the stated range covers the measured number.
By their numbers in this assay, from the lowest: compounds 1, 3 and 4 (each within the scatter of the next); then compound 2.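

In this assay, 4-methoxyphenyl on the amine nitrogen gives a number 4.8 percentage points higher from compound 1 to compound 4 (within the scatter) and a number 4.2 percentage points higher from compound 3 to compound 4 (within the scatter). Against 3-sulfamoylphenyl, the same group gives a number 24.8 percentage points lower from compound 2 to compound 4 (beyond the scatter). A carbon-only ring on this nitrogen is therefore not enough to match compound 2: compound 3 and compound 4 both carry one, yet they read with compound 1, which has pyridin-2-yl.

From the compounds shown here alone, whether the sulfamoyl group itself matters stays open, since a plain phenyl or a methylsulfonylphenyl group on this nitrogen would test it. No measurement here explains why compound 2 stands apart.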